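Swapping the chlorinated ring for a hydroxylated one

The source may report more compounds than this note shows. Statements on the series, on what has been measured and on what is new or still open speak of the compounds shown alone.

Compound 1 `O/N=C(\CCN1CCN(c2ccccn2)CC1)c1ccccc1Cl` sits highest of the three measured compounds in a functional assay on HEK293 cells with D(4) dopamine receptor (Homo sapiens) as the target, read by FLIPR (on this read-out lower numbers stand for smaller maximal responses and higher numbers for larger maximal responses), giving 74%. Compound 2 `O/N=C(\CCN1CCN(c2ccccn2)CC1)c1cccc(F)c1` gives 72%, and compound 3 `N#Cc1cccc(/C(CCN2CCN(c3ccccn3)CC2)=N/O)c1` gives 48%. The unmeasured compound 4 `Cc1ccc(O)c(/C(CCN2CCN(c3ccccn3)CC2)=N/O)c1` differs from compound 1 in one place: 2-hydroxy-5-methylphenyl in place of 2-chlorophenyl on a carbon with a double bond to nitrogen. Two measured steps change the same ring. The step of a number 2 percentage points lower from compound 1 to compound 2 (within the scatter) stayed within the scatter, whereas the step of a number 26 percentage points lower from compound 1 to compound 3 (beyond the scatter) went beyond it. Nothing measured carries a hydrogen-bond donor on this ring, so compound 4 is uncertain; a modest drop or no change beyond the scatter seems most likely. Compound 4 is therefore expected to give about 64%, between 45% and 80%, an estimated step of a number 10 percentage points lower from compound 1 to compound 4 (within the scatter).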

Compound 4, largest response reached (reported as efficacy), in percent of the reference or control that the assay uses: 73%
Compound 4: middle estimate off by 9 percentage points, on the low side; the range from low to high includes it.
By their numbers in this assay, from the lowest: compound 3; then compounds 2, 4 and 1 (each within the scatter of the next).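

In this assay, a ring carrying a hydroxyl and a methyl can replace 2-chlorophenyl on this carbon without a change beyond the scatter, the step being a number 1 percentage points lower from compound 1 to compound 4 (within the scatter). Compared with the fluorinated ring, the step is a number 1 percentage points higher from compound 2 to compound 4 (within the scatter), so a hydrogen-bond donor on this ring does not lower the response here, while compound 3 remains apart, with a number 25 percentage points higher from compound 3 to compound 4 (beyond the scatter). No available evidence accounts for these results.

On these data alone, the hydroxyl and methyl enter together, so their separate contributions remain open. So does the outcome with an amine or a carboxylic acid on this ring.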